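Swapping an acetyl for a hydroxy on a urea

The compounds below may be only part of what the source reports. "The series", "measured", "known", "first", "only" and "open" are said of these compounds alone.

Measured so far:
- Compound 1 `CC(=O)c1ccc(NC(=O)Nc2cc(C)nc3ccccc23)cc1`: in an ADME assay on BJ cells (Homo sapiens) for cytotoxicity, with a stated time of 72 h (a lower number here means that less compound is needed, a higher number that more compound is needed for the effect), compound 1 gives 22000 nM.
- Compound 2 `Cc1cc(NC(=O)Nc2cccc(C(N)=O)c2)c2ccccc2n1`: in this assay compound 2 gives > 25000 nM, which is a limit of the assay rather than a number.
- Compound 3 `Cc1cc(NC(=O)Nc2cnc3ccccc3c2)c2ccccc2n1`: in this assay compound 3 gives > 25000 nM, again a limit of the assay and not a number.

Among these three, compound 1 is the only one with a definite number; the other two sit at the limit of > 25000 nM in this assay, at which 2 of the 3 values shown sit. All three share the same core, and they differ only in the group carried on the other side of the urea.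

The next compound, compound 4 `Cc1cc(NC(=O)Nc2ccc(O)cc2)c2ccccc2n1`, has not yet been tested. It is derived from compound 1 by a single change: hydroxy in place of acetyl on an aromatic carbon.

Among the compounds with values here, no step between two measured compounds is available, so there is no measured change of the same kind to lean on. Compound 1 already sits close to the limit of the assay, and the two other compounds reach that limit. The step from compound 1 to compound 4 is therefore expected to be small, if any, with a fair chance that compound 4 lands at the limit as well; the expected step is a 1.1-fold higher number from compound 1 to compound 4 (0.06 log units; within the scatter).

Compound 4 is estimated at 25000 nM, with a range from 12000 nM to 50000 nM.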

Compound 4, half-maximal effective concentration: > 25000 nM
Compound 4 gave a limit, no number; the forecaster's own chance of this, stated with the estimate: 50%; the middle value sits exactly at the limit.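

In this assay, hydroxy in place of acetyl on this aromatic carbon gives an at least 1.1-fold higher number from compound 1 to compound 4 (0.05 log units; that floor lies within the scatter), the first step read at this place on the shared core. For compound 4, the value of > 25000 nM is a limit of the assay and not a number. The change therefore shows that losing the acetyl, with its carbonyl, and adding the hydrogen-bond donor of a hydroxy does not bring a definite number back into range, but the true size of the step stays hidden, and this series offers little room to see differences: the limit of > 25000 nM in this assay, at which 3 of the 4 values shown sit.

Within the data shown here, the floor of this step lies within the scatter, so the data do not show whether the acetyl of compound 1 truly makes it differ from compound 4, and compound 1 remains the only compound with a definite number. Also open, from the compounds shown here alone, is how other groups at this same position, such as an amine, a carboxylic acid or a methoxy group, would behave, and whether any of them would give a definite number rather than a limit.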